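The source may hold more compounds than are shown below. What is called first, only, known or untested is meant among the compounds shown, and "the series" means these compounds.

- compound 1 `O=C(/C=C/c1ccc(O)c(O)c1)N1CCN(c2ccc(F)cc2)CC1`: 1.25 ug/mL
- compound 2 `COc1cccc(N2CCN(C(=O)/C=C/c3ccc(O)c(O)c3)CC2)c1`: 1.27 ug/mL

Within the data shown here, in a functional assay on A549 cells (Homo sapiens) for antiproliferative activity, read by MTT assay, with a stated time of 48 h (on this read-out higher numbers stand for weaker inhibition and lower numbers for stronger inhibition), compound 2 stands level with compound 1, the only other measured compound, and the two values lie within the scatter. Compound 3 `Cc1ccc(N2CCN(C(=O)/C=C/c3ccc(O)c(O)c3)CC2)c(C)c1` carries 2,4-dimethylphenyl in place of 3-methoxyphenyl on an amine nitrogen in a ring. Among the measured compounds shown here, the single measured step bearing on this is an exchange at that same nitrogen, a 1.0-fold higher number from compound 1 to compound 2 (0.01 log units; within the scatter). On this one step, no change beyond the scatter is expected in this assay. The expected step is a 1.0-fold higher number from compound 2 to compound 3 (0.01 log units; within the scatter). For compound 3 the estimate is 1.3 ug/mL, with an expected range of 0.6 ug/mL to 3 ug/mL.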

Compound 3, half-maximal inhibitory concentration: 1.02 ug/mL
Estimate against measurement, compound 3: 1.3-fold (0.11 log units) above; measured number inside the range.
By their numbers in this assay, from the lowest: compounds 3, 1 and 2 (each within the scatter of the next).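

In this assay the amine nitrogen in the ring now accepts a third substituted phenyl group with no change beyond the scatter, giving a 1.2-fold lower number from compound 2 to compound 3 (0.10 log units; within the scatter) and a 1.2-fold lower number from compound 1 to compound 3 (0.09 log units; within the scatter). This holds for 2,4-dimethylphenyl, which has no hydrogen-bond acceptor, whereas 3-methoxyphenyl has one. No supporting evidence bears on why these numbers stay so close. The compounds shown leave open whether a carboxylic acid or an amine on this phenyl ring, or a plain alkyl chain in its place, would hold the number in this range.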